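Guanidine for a hydrogen on the terminal amine

This account rests on a few compounds, and the source may have more. Where it says the series, first, only, none or still open, it means among the compounds named here.

Compound 1 `CCN(CC)CC[n+]1c(SCC(=O)NCCN)[nH]c2c(C)nc(N(CC)CC)nc21` is the reference point. Among the compounds with values here, in an ADME assay on CEM174 cells (Homo sapiens) for cytotoxicity (a lower number here means that less compound is tolerated, a higher number that more compound is tolerated), compound 1 gives 52.2 uM and stands as the only number among the three measured compounds. For compound 2 `CCN(CC)c1nc(C)c2[nH]c(SCC(=O)NCCN)[n+](CCCN(C)C)c2n1` the result is a limit, > 100 uM. For compound 3 `CCN(CC)c1nc(C)c2[nH]c(SCC(=O)NCCCNC(=N)N)nc2n1` the result is likewise a limit, > 100 uM. Within the data shown here, the one measured step is an at least 1.9-fold higher number from compound 1 to compound 2 (0.28 log units; that floor lies within the scatter), and it does not reach beyond the scatter. Compound 4 `CCN(CC)CC[n+]1c(SCC(=O)NCCNC(=N)N)[nH]c2c(C)nc(N(CC)CC)nc21` differs from compound 1 by a group of 3 heavy atoms (1 carbon, 2 nitrogen; no ring) in place of a hydrogen atom, on an amine nitrogen. Among the measured compounds shown here, no measured step covers this exact change; compound 3 carries a guanidine on a chain but differs from compound 1 in more than one place, so only its limit can be noted. The nearest measured step, from compound 1 to compound 2, was small, and the shared core is unchanged. Compound 4 is therefore expected to stay within the scatter of compound 1, a step of a 1.3-fold higher number from compound 1 to compound 4 (0.13 log units; within the scatter), with an estimate of 70 uM in this assay, ranging from 30 uM to 160 uM.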

Compound 4, half-maximal toxic concentration: > 100 uM
Compound 4 was reported as a limit; the forecaster's own chance of this, stated with the estimate: 35%; middle value at least 1.4-fold (0.15 log units) away from the limit.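

In this assay, the change on the amine nitrogen gives an at least 1.9-fold higher number from compound 1 to compound 4 (0.28 log units; that floor lies within the scatter). Within the data shown here, this is the first direct reading of the group of 3 heavy atoms at this place, and it shows no fall in the tolerated concentration, which compound 3 could not show as it differs from compound 1 in more than one place. The real size of the step cannot be read, because the reading for compound 4 ends at a limit, as most of the readings here do: the limit of > 100 uM in this assay, at which 3 of the 4 values shown sit.

As far as these compounds go, whether the step truly stays within the scatter or goes beyond it remains open. Also open, from the compounds shown here alone, is how a methyl or an acetyl group on the same amine nitrogen, or a longer chain carrying the amine, would read in this assay.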